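This account rests on a few compounds, and the source may have more. Where it says the series, first, only, none or still open, it means among the compounds named here.

Compound 1, `O=C(NO)c1cccc(-c2cn([C@H]3C[C@H](C(=O)O)N(Cc4ccccc4)C3)nn2)c1`: in an assay on Sf9 cells for inhibition of histone deacetylase 11 (Homo sapiens), read by fluorescence, tested at 0.5 uM (a higher number here means more inhibition at the concentration tested (going by the name of the read-out), a lower number less inhibition), compound 1 gives < 10%, which is a limit of the assay and not a number.
Compound 2, `O=C(NO)c1cccc(-c2cn([C@H]3C[C@H](CO)N(Cc4ccccc4)C3)nn2)c1`: in this assay compound 2 gives < 10%, again a limit.
Compound 3, `O=C(NO)c1ccc(-c2cn([C@H]3C[C@@H](CO)N(CCCc4ccccc4)C3)nn2)cc1`: in this assay compound 3 gives < 10%, also a limit.

All three measured compounds therefore sit at the same limit, and this is the whole of the evidence: the limit of < 10% in this assay, at which 3 of the 3 values shown sit. For the measured compounds named here, the one change that has been made between measured compounds is carboxy in place of hydroxymethyl on a saturated ring carbon, and the step it produced, a step that the two limits leave unreadable from compound 2 to compound 1, cannot be sized because both ends are limits. Compound 4, `O=C(NO)c1ccc(-c2cn([C@H]3C[C@@H](C(=O)O)N(CCCc4ccccc4)C3)nn2)cc1`, has not been measured in this assay. Going by the values given here, it arises from compound 3 by carboxy in place of hydroxymethyl on a saturated ring carbon, the same kind of change as the one from compound 2 to compound 1, but not the same: in compound 4 the saturated ring carbon is next to the ring atom that bears a 3-phenylpropyl group, whereas in compound 1 it is next to the ring atom that bears a benzyl group. The difference between the cores of compound 2 and compound 3 is not broken down here.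

With every shown value at the limit, the step from compound 3 to compound 4 in this assay is expected to be small, a step that the limit leaves unreadable from compound 3 to compound 4, because the matching change produced a step that the two limits leave unreadable from compound 2 to compound 1 without leaving the limit. Compound 4 is accordingly estimated at 5%, with a likely range from 0% to 15%, and most probably it will again be reported only as a limit.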

Compound 4, a percentage reported as inhibition, at one concentration (the size of the read-out at that concentration, not a potency): 14%
Compound 4: the middle estimate sits 9 percentage points below what was measured; the measured number falls inside the stated range.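

On the core of compound 3, carboxy in place of hydroxymethyl on a saturated ring carbon gives a number at least 4 percentage points higher from compound 3 to compound 4 (that floor lies within the scatter) in this assay, so this result alone does not establish a real rise. The same kind of change on the core of compound 2 cannot be read, as both of its ends are limits, and the two steps therefore cannot be set side by side: nothing here shows that the change carries from one core to the other, or that it fails to carry. The result adds one readable number to a set that otherwise remains at a single limit: the limit of < 10% in this assay, at which 3 of the 4 values shown sit.

The compounds shown leave open whether the step depends on the 3-phenylpropyl group, the benzyl group or the other differences between the two cores, as no single change separates these. They also leave open how an amine or a primary amide in place of the carboxy, or a longer chain in place of the 3-phenylpropyl group, would read in this assay, and whether any such compound would stand clear of the scatter.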